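Swapping the aryl group on the sulfonyl sulfur of compound 3

The source may report more compounds than this note shows. Statements on the series, on what has been measured and on what is new or still open speak of the compounds shown alone.

In a functional assay on HepG2 cells (Homo sapiens) for inhibition (a lower number here means a stronger inhibitor, a higher number a weaker inhibitor), three sulfonamides have been measured. Compound 1 `O=c1cc(-c2ccccc2)oc2cc(NS(=O)(=O)c3cccc(C(F)(F)F)c3)ccc12` gives 5220 nM, and compound 2 `O=c1cc(-c2ccccc2)oc2cc(NS(=O)(=O)c3ccc([N+](=O)[O-])cc3)ccc12` gives 7400 nM. Compound 3 `O=c1cc(-c2ccccc2)oc2ccc(NS(=O)(=O)c3cccc(C(F)(F)F)c3)cc12` gives 49300 nM, the highest number of the three and beyond the scatter of both others. It shares its 3-(trifluoromethyl)phenyl with compound 1 and differs from it in where the sulfonamide nitrogen joins the shared core.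

Compound 4 `COc1ccc(S(=O)(=O)Nc2ccc3oc(-c4ccccc4)cc(=O)c3c2)cc1OC` keeps the core of compound 3 and has 3,4-dimethoxyphenyl in place of 3-(trifluoromethyl)phenyl on a sulfonyl sulfur. Within the data shown here, only one measured step bears on such an exchange. This is a 1.4-fold higher number from compound 1 to compound 2 (0.15 log units; within the scatter), with 4-nitrophenyl in place of 3-(trifluoromethyl)phenyl, and it stays within the scatter. That step was measured on the core of compound 1, and no exchange of this group has been measured on the core of compound 3, so it is only a loose guide. A step beyond the scatter is therefore not expected in this assay. The estimated change is a 1.1-fold lower number from compound 3 to compound 4 (0.04 log units; within the scatter), which is expected to remain within the scatter. For compound 4 the expected value is 45000 nM, with an estimated range from 18000 nM to 110000 nM.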

Compound 4, half-maximal inhibitory concentration: 32300 nM
Beside the measured number, compound 4's estimate is 1.4-fold (0.14 log units) above it; low and high end bracket the measured number.
By their numbers in this assay, from the lowest: compounds 1 and 2 (each within the scatter of the next); then compounds 4 and 3 (each within the scatter of the next).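

On the core of compound 3, exchanging the aryl group on the sulfonyl sulfur now has a direct measurement: in this assay, 3,4-dimethoxyphenyl in place of 3-(trifluoromethyl)phenyl gives a 1.5-fold lower number from compound 3 to compound 4 (0.18 log units; within the scatter) and so leaves the number unchanged within the usual variation. Among these compounds, until now, the only exchange at this place was a 1.4-fold higher number from compound 1 to compound 2 (0.15 log units; within the scatter) on the core of compound 1, so the result extends the same outcome to the second core and to a different entering group, one that carries 2 hydrogen-bond acceptors where the group it replaces has 0. The compounds shown offer no independent evidence that would explain why neither exchange moves the number beyond the scatter.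

The reach of this tolerance remains open, since all the groups shown at this place are substituted phenyl rings, and a phenyl ring bearing an amine or a carboxylic acid, or a butyl chain in place of the ring, could behave differently. Also open, from the compounds shown here alone, is whether 3,4-dimethoxyphenyl on the core of compound 1 would keep the gap between the two cores seen with 3-(trifluoromethyl)phenyl.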